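A few compounds are considered here, and "the series" means these few. Any claim that something is new, unique, unknown or untested is made for them only; others in the source may bear on it.

Working notes on the series. Three compounds share one core and differ only in the substituent on the benzyl ring, at the place where the cyano of compound 3 sits. Compound 1 `FC(F)(F)c1ccccc1-c1nc(NCc2ccc(Cl)cc2)c2ccccc2n1` gives 4800 nM in an assay on a protein complex for inhibition of ubiquitin carboxyl-terminal hydrolase 1/WD repeat-containing protein 48 (Homo sapiens), read by fluorescence; a higher number here means a weaker inhibitor, a lower number a stronger inhibitor. Compound 2 `FC(F)(F)c1ccc(CNc2nc(-c3ccccc3C(F)(F)F)nc3ccccc23)cc1` gives 8900 nM. Compound 3 `N#Cc1ccc(CNc2nc(-c3ccccc3C(F)(F)F)nc3ccccc23)cc1` gives 5700 nM, which places it second highest of the three numbers, nearest to compound 1 and furthest from compound 2. The steps at this position are all small: a 1.9-fold higher number from compound 1 to compound 2 (0.27 log units; within the scatter), a 1.2-fold higher number from compound 1 to compound 3 (0.07 log units; within the scatter) and a 1.6-fold lower number from compound 2 to compound 3 (0.19 log units; within the scatter). Compound 4 `FC(F)(F)c1ccccc1-c1nc(NCc2ccc(-c3ccccc3)cc2)c2ccccc2n1` carries the change (phenyl in place of cyano on an aromatic carbon). Among the compounds with values here, no measured step introduces a phenyl, so none bears directly on it; the three steps at the same place, all within the scatter, are the only guide and point to no change beyond the scatter. Compound 4 is therefore expected to show a 1.1-fold higher number from compound 3 to compound 4 (0.02 log units; within the scatter) in this assay, with a wide allowance for the untested group. The estimate for compound 4 is 6000 nM, ranging from 2000 nM to 18000 nM.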

Compound 4, half-maximal inhibitory concentration: 3700 nM
Estimate against measurement, compound 4: 1.6-fold (0.21 log units) above, within the range that was stated.
By their numbers in this assay, from the lowest: compounds 4, 1, 3 and 2 (each within the scatter of the next, the first and the last beyond it).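

In this assay this position, para to a large group, accommodates a whole six-membered aromatic ring of carbon only in place of the smaller groups, with no clear change against two of them: a 1.5-fold lower number from compound 3 to compound 4 (0.19 log units; within the scatter) and a 1.3-fold lower number from compound 1 to compound 4 (0.11 log units; within the scatter) both stay within the scatter. Phenyl does, however, give the first step at this position that lies beyond the scatter, a 2.4-fold lower number from compound 2 to compound 4 (0.38 log units; beyond the scatter), modest in size and seen only against trifluoromethyl. Nothing available explains these numbers.

Open, on these data alone, is whether an amine, a carboxylic acid or a longer chain at this place would move the number beyond the scatter against compound 1 and compound 3. As far as these compounds go, all four compounds also keep the shared core unchanged, so whether the same steps would hold on a different core remains unknown.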